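A few compounds are considered here, and "the series" means these few. Any claim that something is new, unique, unknown or untested is made for them only; others in the source may bear on it.

Compound 1 `COc1ccc(SCc2ccc(/C=C/C(=O)Nc3ccccc3N)cc2)cc1OC`: 44.6%
Compound 2 `Nc1ccccc1NC(=O)/C=C/c1ccc(CSc2ccc(Cl)cc2)cc1`: 16.5%
Compound 3 `Nc1ccccc1NC(=O)/C=C/c1ccc(CSc2cccc(F)c2)cc1`: 8.25%

All three values come from a functional assay on SMMC-7721 cells (Homo sapiens) for inhibition, read by CCK-8 assay, with a stated time of 72 h, tested at 8 uM; on this read-out lower numbers stand for less inhibition of growth and higher numbers for more inhibition of growth at the one concentration tested. Compound 3 stands well under compound 1, a number 36.4 percentage points lower from compound 1 to compound 3 (beyond the scatter), and level with compound 2 within the scatter, a number 8.3 percentage points lower from compound 2 to compound 3 (within the scatter). Compound 4 `CCc1ccc(SCc2ccc(/C=C/C(=O)Nc3ccccc3N)cc2)cc1` differs from compound 3 at one place, the group on the sulfur: 4-ethylphenyl in place of 3-fluorophenyl on a sulfur. Only the group on the sulfur varies across the measured set. The change from 3,4-dimethoxyphenyl gave a number 28.1 percentage points lower from compound 1 to compound 2 (beyond the scatter) as well as the step to compound 3, so this group can move the read-out. Going by the values given here, no measured compound carries an alkyl-substituted ring, so the direction is weakly supported. A small rise is expected: a number 8.8 percentage points higher from compound 3 to compound 4 (within the scatter). Compound 4 is estimated at 17%, with an expected range of 4% to 38%.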

Compound 4, percent growth inhibition at one concentration: 19.5%
Compound 4: middle estimate off by 2.5 percentage points, on the low side; low and high end bracket the measured number.
By their numbers in this assay, from the lowest: compounds 3, 2 and 4 (each within the scatter of the next, the first and the last beyond it); then compound 1.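

In this assay an alkyl group on the ring carried by the sulfur gives a number 11.3 percentage points higher from compound 3 to compound 4 (beyond the scatter) and the ethyl for chloro exchange gives a number 3 percentage points higher from compound 2 to compound 4 (within the scatter) so this position accepts ethyl with a read-out level with chloro. The 3,4-dimethoxyphenyl group remains apart with a number 25.1 percentage points lower from compound 1 to compound 4 (beyond the scatter) and the 4-ethylphenyl group does not reach compound 1. No available evidence accounts for these differences.

Open, as far as these compounds go, is whether a single methoxy group keeps the read-out of compound 1. Also open, from the compounds shown here alone, is how a longer chain or an amine on this ring would read.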